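A phenyl swap on a benzamide-bearing amide scaffold

The source may report more compounds than this note shows. Statements on the series, on what has been measured and on what is new or still open speak of the compounds shown alone.

Compound 1 `Cc1ccc(CNC(=O)CN(CCCCCC(=O)Nc2ccccc2N)C(=O)c2cc(C)cc(C)c2)cc1`: > 10000 nM
Compound 2 `CN(C)c1ccc(C(=O)N(CC(=O)NCc2ccccc2)Cc2ccc(C(=O)Nc3ccccc3N)cc2)cc1`: > 10000 nM

Both results in an assay on Sf9 cells for inhibition of protein deacetylase HDAC6 (Homo sapiens), read by fluorescence, with a stated time of 90 min (a higher number here means a weaker inhibitor, a lower number a stronger inhibitor), are limits of the assay rather than numbers. Compound 1 reaches only the limit > 10000 nM in this assay. Compound 2 likewise reaches only the limit > 10000 nM. Among the compounds with values here, compound 2 therefore stands at the limit of > 10000 nM in this assay, at which 2 of the 2 values shown sit, and no step between measured compounds is available.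

Compound 3 `Cc1cc(C)cc(C(=O)N(CC(=O)NCc2ccccc2)Cc2ccc(C(=O)Nc3ccccc3N)cc2)c1` differs from compound 2 in one place: 3,5-dimethylphenyl in place of 4-(dimethylamino)phenyl on a carbonyl carbon. The entering group already appears in compound 1, whose own result in this assay is a limit. Within the data shown here, no measured step shows the effect of this change. The step that the limit leaves unreadable from compound 2 to compound 3 is expected to be none beyond the scatter, and this assay may well again report only a limit. Compound 3 is expected to give about 15000 nM, within 5000 nM to 50000 nM.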

Compound 3, half-maximal inhibitory concentration: > 10000 nM
Compound 3 gave a limit, no number; the forecaster's own chance of this, stated with the estimate: 80%; the middle value does not contradict the limit.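

In this assay compound 3 gives only a limit, > 10000 nM, and no step can be read between compound 2 and compound 3. The compounds shown leave open whether 3,5-dimethylphenyl or 4-(dimethylamino)phenyl on the carbonyl carbon makes any difference to inhibition, as every result shown is the same limit: the limit of > 10000 nM in this assay, at which 3 of the 3 values shown sit.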